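Removing the methyl from compound 2's aryl ether

A few compounds are considered here, and "the series" means these few. Any claim that something is new, unique, unknown or untested is made for them only; others in the source may bear on it.

Of the compounds shown here, three have been measured in a functional assay on MDA-MB-468 cells (Homo sapiens) for inhibition, read by sulforhodamine B assay, with a stated time of 48 h; on this read-out lower numbers stand for stronger inhibition and higher numbers for weaker inhibition. Compound 1 `O=C(Nc1cccc(-n2cc(-c3ccncc3)c(-c3ccc(Cl)c(O)c3)n2)c1)Nc1cccc(C(F)(F)F)c1` gives 980 nM, compound 3 `COc1cc(-c2nn(-c3cccc(NC(=O)Nc4cccc(C(F)(F)F)c4)c3)cc2-c2ccncc2)ccc1Cl` gives 600 nM, and compound 2 `COc1cc(-c2nn(-c3cccc(NC(=O)Nc4cc(C(F)(F)F)cc(C(F)(F)F)c4)c3)cc2-c2ccncc2)ccc1Cl` gives 310 nM, the lowest of the three numbers, though its gap to compound 3 stays within the scatter and only its gap to compound 1 lies beyond it. Compound 4 `O=C(Nc1cccc(-n2cc(-c3ccncc3)c(-c3ccc(Cl)c(O)c3)n2)c1)Nc1cc(C(F)(F)F)cc(C(F)(F)F)c1` differs from compound 2 by hydrogen in place of methyl on an oxygen on an aromatic ring. Going by the values given here, the one measured step of this kind runs the other way, from compound 1 to compound 3, where the methyl was added: a 1.6-fold lower number from compound 1 to compound 3 (0.21 log units; within the scatter). The other measured step, a 1.9-fold higher number from compound 2 to compound 3 (0.29 log units; within the scatter), concerns the trifluoromethyl and does not bear on the change at the oxygen. Read in reverse, the step from compound 1 to compound 3 suggests that taking the methyl away should give at most a slightly higher number, not beyond the scatter. Compound 4 is therefore expected to give 500 nM in this assay, in the range 250 nM to 1000 nM, and the estimated step of a 1.6-fold higher number from compound 2 to compound 4 (0.21 log units; within the scatter) is expected to stay within the scatter.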

Compound 4, half-maximal inhibitory concentration: 270 nM
Compound 4: middle estimate off by 1.9-fold (0.27 log units), on the high side, within the range that was stated.
By their numbers in this assay, from the lowest: compounds 4, 2, 3 and 1 (each within the scatter of the next, the first and the last beyond it).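

On the core of compound 2, methoxy to hydroxy gives a 1.1-fold lower number from compound 2 to compound 4 (0.06 log units; within the scatter) in this assay and so leaves the number within the scatter on a second core. The change at this oxygen reads alike on both cores: the same change on two cores in this assay, a 1.6-fold lower number (0.21 log units; within the scatter) from compound 1 to compound 3 and a 1.1-fold higher number (0.06 log units; within the scatter) from compound 4 to compound 2, 1.9-fold (0.27 log units) apart, within the scatter of two such steps.

The new compound also gives a second reading of trifluoromethyl in place of hydrogen on an aromatic carbon, with a 3.6-fold lower number from compound 1 to compound 4 (0.56 log units; beyond the scatter) now beyond the scatter, although this step and the earlier one on the methoxy core do not differ beyond it: the same change on two cores in this assay, a 1.9-fold higher number (0.29 log units; within the scatter) from compound 2 to compound 3 and a 3.6-fold higher number (0.56 log units; beyond the scatter) from compound 4 to compound 1, 1.9-fold (0.27 log units) apart, within the scatter of two such steps.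

In this assay, on these data alone, it stays open whether an ethyl on the oxygen, or an amine in place of the hydroxy, would keep the number in this range. The compounds shown also leave open how methoxy and hydroxy compare on a core without trifluoromethyl.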